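The source may hold more compounds than are shown below. What is called first, only, known or untested is meant among the compounds shown, and "the series" means these compounds.

Of the compounds shown here, three sharing a common skeleton have been measured in a physicochemical assay, with a stated time of 60 min; a lower number here means a stronger inhibitor, a higher number a weaker inhibitor. Compound 1 `CCOC(=O)[C@@H]1C(=O)N(Cc2ccccc2)C[C@@H](ON2C(C)(C)CCCC2(C)C)[C@H]1c1ccc(F)cc1` gives 15900 nM. Compound 2 `CC1(C)CCCC(C)(C)N1O[C@@H]1CN(Cc2ccccc2)C[C@@H](CO)[C@@H]1c1ccc(F)cc1` gives 95 nM, the lowest of the three. Compound 3 `CCOC(=O)[C@@H]1C(=O)N(Cc2ccccc2)C[C@@H](ON2C(C)(C)CCCC2(C)C)[C@H]1c1ccc(C)cc1` gives 98400 nM. Compound 3 differs from compound 1 by methyl in place of fluoro on an aromatic carbon, and this change gave a 6.2-fold higher number from compound 1 to compound 3 (0.79 log units; beyond the scatter). The difference between the core of compound 1 and that of compound 2 is not broken down here.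

Compound 4 `Cc1ccc([C@H]2[C@H](CO)CN(Cc3ccccc3)C[C@H]2ON2C(C)(C)CCCC2(C)C)cc1` is not yet measured. It differs from compound 2 by methyl in place of fluoro on an aromatic carbon, the same change as from compound 1 to compound 3. Compound 4 is expected to give a weaker number than compound 2, with a step of a 5.8-fold higher number from compound 2 to compound 4 (0.76 log units; beyond the scatter), close to the earlier 6.2-fold higher number from compound 1 to compound 3 (0.79 log units; beyond the scatter), though the cores differ. For compound 4 the estimate is 550 nM, likely between 150 nM and 2000 nM.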

Compound 4, half-maximal inhibitory concentration: 90 nM
Beside the measured number, compound 4's estimate is 6.1-fold (0.79 log units) above it; measured number below the stated range.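

In this assay the change from 4-fluorophenyl to 4-methylphenyl gives a result within the scatter on one core (a 1.1-fold lower number from compound 2 to compound 4 (0.02 log units; within the scatter)), but a result beyond the scatter on the other (a 6.2-fold higher number from compound 1 to compound 3 (0.79 log units; beyond the scatter)). So in these two pairs the step seen on one core did not carry over to the other, although two pairs cannot show how any other core would respond. Nothing measured here explains why the two cores part ways.

The compounds shown carry only fluoro and methyl at this place on the ring, so it remains open how a group such as chloro, methoxy or nitrile would behave there on each core. Also open, as far as these compounds go, is which part of the difference between the two cores matters for this change.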